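The compounds below may be only part of what the source reports. "The series", "measured", "known", "first", "only" and "open" are said of these compounds alone.

For the measured compounds named here, compound 1 `Cc1c(Nc2ccc(C#N)cc2Cl)ncnc1OC1C2COCC1CN(C(=O)OC1(C)CC1)C2` gives 4 nM in a functional assay on HEK293 cells for agonist activity at Glucose-dependent insulinotropic receptor (Homo sapiens), read by fluorescence and cAMP accumulation, with a stated time of 30 min (a higher number here means that more compound is needed for the effect, a lower number that less compound is needed), the lowest of the two numbers in hand; compound 2 `CC1(OC(=O)N2CC3COCC(C2)C3Oc2cc(Nc3ccc(C#N)cc3Cl)ncn2)CC1` gives 25 nM, and the only measured step, a 6.3-fold higher number from compound 1 to compound 2 (0.80 log units; beyond the scatter), concerns hydrogen in place of methyl on an aromatic carbon. Compound 3 `Cc1c(Oc2ccc(C#N)cc2Cl)ncnc1OC1C2COCC1CN(C(=O)OC1(C)CC1)C2` differs from compound 1 in another way: 2-chloro-4-cyanophenoxy in place of (2-chloro-4-cyanophenyl)amino on an aromatic carbon. Going by the values given here, no measured step touches this exchange of the amino linkage for an oxygen linkage, so the expectation rests on the change alone, with the loss of the single hydrogen-bond donor. Compound 3 is estimated at 15 nM, within 3 nM to 80 nM, a step of a 3.8-fold higher number from compound 1 to compound 3 (0.57 log units; beyond the scatter) expected toward a higher number.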

Compound 3, half-maximal effective concentration: 16 nM
Estimate against measurement, compound 3: 1.1-fold (0.03 log units) below; the range from low to high includes it.
By their numbers in this assay, from the lowest: compound 1; then compounds 3 and 2 (each within the scatter of the next).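

For the compounds shown here, the earlier compounds spoke only to the methyl group; this result is the first to concern the linkage to the 2-chloro-4-cyanophenyl ring. In this assay, the entering 2-chloro-4-cyanophenoxy group carries no hydrogen-bond donor, and the step is a 4.0-fold higher number from compound 1 to compound 3 (0.60 log units; beyond the scatter), so the amino linkage is favoured here but is not essential for activity. Nothing at hand explains this difference. The compounds shown leave open how a sulfur or methylene linkage would read at this place, and whether the step seen on replacing the methyl with hydrogen holds with the phenoxy group present.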